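The compounds below may be only part of what the source reports. "The series", "measured", "known", "first", "only" and "open" are said of these compounds alone.

Working notes on the series. The shared core is carried by compound 1 `O=C(Oc1ccc(-c2ccc(F)cc2F)cc1C(=O)O)c1ccccc1`, compound 2 `CC(=O)Oc1ccc(-c2ccc(F)cc2F)cc1C(=O)Nc1ccccc1` and compound 3 `CC(=O)Oc1ccc(-c2ccc(F)cc2F)cc1C(=O)Nc1cc(C)ccc1C`. In a functional assay on the whole organism (strain Kunming) for inhibition, with Mus musculus as the target, in the writhing test, at a dose of 40 mg/kg by the oral route (a higher number here means more inhibition at the dose given (going by the name of the read-out), a lower number less inhibition), compound 1 gives 7.97%, compound 2 gives 8.9% and compound 3 gives 13.2%. Going by the values given here, compound 2 thus stands second of the three numbers, with compound 1 as its nearest neighbour and compound 3 as its furthest; the one single-point step recorded, a number 4.3 percentage points higher from compound 2 to compound 3 (within the scatter), lies within the scatter, and all three numbers sit together.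

The compound not yet measured is compound 4 `O=C(Oc1ccc(-c2ccc(F)cc2F)cc1C(=O)Nc1ccccc1)c1ccccc1`. Against compound 2 the change is phenyl in place of methyl on a carbonyl carbon, that is, acetyl to benzoyl on the ester. Among the compounds with values here, no measured step touches this position: the step from compound 2 to compound 3 concerns the amide-type nitrogen, and compound 1, which carries the benzoyloxy group, differs from compound 2 in two places, so its value is only a hint that a benzoyl ester sits in the same low range. For compound 4 in this assay a step of a number 0.1 percentage points higher from compound 2 to compound 4 (within the scatter) is therefore expected, none beyond the scatter. Compound 4 is estimated at 9%, within 3% to 16%.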

Compound 4, a percentage reported as inhibition, in the whole organism at one dose (the size of the read-out at that dose, not a potency): 5.57%
Beside the measured number, compound 4's estimate is 3.4 percentage points above it, within the range that was stated.
By their numbers in this assay, from the lowest: compounds 4, 1, 2 and 3 (each within the scatter of the next).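

In this assay the ester position now has a direct reading: acetyl to benzoyl on the anilide gives a number 3.3 percentage points lower from compound 2 to compound 4 (within the scatter), so six heavy atoms entering for one on this carbonyl carbon leave the number within the scatter. With the benzoyloxy group held in place, anilino in place of hydroxy on a carbonyl carbon gives a number 2.4 percentage points lower from compound 1 to compound 4 (within the scatter), a single-place comparison of the acid and the anilide that the two-place difference between compound 1 and compound 2 could not give. Nothing measured on these compounds bears on why the numbers sit as they do.

Going by these compounds, what a longer chain such as butanoyl, or a free hydroxy group in place of the ester, would do at this position stays open. Also open, on these data alone, is whether benzoyl and the 2,5-dimethylphenyl group on the amide-type nitrogen would combine to give a number beyond the scatter.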